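Swapping One Ring on Two Related Cores

The source may report more compounds than this note shows. Statements on the series, on what has been measured and on what is new or still open speak of the compounds shown alone.

Compound 1 `COc1ccccc1/C=C(\C(=O)c1ccc(Br)cc1)S(=O)(=O)c1ccc(C)cc1` and compound 2 `Cc1ccc(S(=O)(=O)/C(=C/c2sccc2C)C(=O)c2ccc(Br)cc2)cc1` share one core. Within the data shown here, in a functional assay on DU-145 cells (Homo sapiens) for inhibition, read by trypan blue exclusion, with a stated time of 96 h (on this read-out higher numbers stand for weaker inhibition of growth and lower numbers for stronger inhibition of growth), compound 1 gives 1000 nM, while compound 2 gives 25000 nM; the single change between them, (3-methylthiophen-2-yl in place of 2-methoxyphenyl on a double-bonded chain carbon bound to a double-bonded chain carbon), made the step of a 25-fold higher number from compound 1 to compound 2 (1.40 log units; beyond the scatter). Compound 3 `COc1ccccc1/C=C(\C(=O)c1ccc(Cl)cc1)S(=O)(=O)Cc1ccc(C)cc1` sits on a second core, and the difference between the two cores is not broken down here. In this assay compound 3 gives 10000 nM. Compound 4 `Cc1ccc(CS(=O)(=O)/C(=C/c2sccc2C)C(=O)c2ccc(Cl)cc2)cc1` carries the same change on this second core, (3-methylthiophen-2-yl in place of 2-methoxyphenyl on a double-bonded chain carbon bound to a double-bonded chain carbon). Among the measured compounds shown here, only one earlier pair shows how this change acts, so its size on the second core is uncertain. For compound 4 the expected step is a 15-fold higher number from compound 3 to compound 4 (1.18 log units; beyond the scatter), set a little smaller than a 25-fold higher number from compound 1 to compound 2 (1.40 log units; beyond the scatter). A single pair is a thin basis for this. Compound 4 is therefore expected to give about 150000 nM, likely between 30000 nM and 600000 nM.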

Compound 4, concentration for 50% growth inhibition: 25000 nM
For compound 4 the middle estimate is 6.0-fold (0.78 log units) above the measured one; measured number below the stated range.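

On the second core the swap again raises the number, but by much less: a 2.5-fold higher number from compound 3 to compound 4 (0.40 log units; beyond the scatter). Among these compounds, the change therefore points the same way on both cores in this assay, yet its size does not carry over from one core to the other: the same change on two cores in this assay, a 25-fold higher number (1.40 log units; beyond the scatter) from compound 1 to compound 2 and a 2.5-fold higher number (0.40 log units; beyond the scatter) from compound 3 to compound 4, 10-fold (1.00 log units) apart, beyond the scatter of two such steps These two pairs show only that a step measured on one core cannot be assumed to hold in size on the other; they do not show why the steps differ, and they set no rule for the wider series.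

Which feature separating the two cores goes with the smaller step remains open. So does how a ring bearing an amine or a carboxylic acid would behave in place of 2-methoxyphenyl.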